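Fluorophenyl shift on a three-aryl pyridine core

This account rests on a few compounds, and the source may have more. Where it says the series, first, only, none or still open, it means among the compounds named here.

Measured compounds in a functional assay on HeLa cells (Homo sapiens) for inhibition; on this read-out higher numbers stand for weaker inhibition and lower numbers for stronger inhibition:
compound 1 `Oc1ccc(-c2cc(-c3cccc(F)c3)cc(-c3ccccc3O)n2)cc1`: > 50000 nM
compound 2 `Oc1ccc(-c2cc(-c3ccc(F)cc3)cc(-c3ccccc3O)n2)cc1`: > 50000 nM
compound 3 `Oc1ccc(-c2cc(-c3cccc(F)c3)cc(-c3cccc(O)c3)n2)cc1`: 14200 nM

The value of compound 1 is a limit of this assay, not a number. The value of compound 2 is likewise a limit. Within the data shown here, compound 3 is the only compound with a number; the step of an at least 3.5-fold lower number from compound 1 to compound 3 (0.54 log units; beyond the scatter) comes with 3-hydroxyphenyl in place of 2-hydroxyphenyl on an aromatic carbon and is read against (the limit of > 50000 nM in this assay, at which 2 of the 3 values shown sit).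

The change 4-fluorophenyl in place of 3-fluorophenyl on an aromatic carbon gives a step that the two limits leave unreadable from compound 1 to compound 2. Compound 4 `Oc1ccc(-c2cc(-c3ccc(F)cc3)cc(-c3cccc(O)c3)n2)cc1` carries the same kind of change, (4-fluorophenyl in place of 3-fluorophenyl on an aromatic carbon), but the place differs: in compound 1 it is meta to a 2-hydroxyphenyl group, in compound 3 meta to a 3-hydroxyphenyl group. The earlier step is unreadable, so nothing measured sets the size here. Compound 4 is therefore expected to stay near compound 3, with an estimated step of a 1.3-fold higher number from compound 3 to compound 4 (0.10 log units; within the scatter). The sole anchor for this expectation is compound 3 with its value 14200 nM. The estimate for compound 4 in this assay is 18000 nM, between 6000 nM and 50000 nM.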

Compound 4, half-maximal inhibitory concentration: 8080 nM
Estimate against measurement, compound 4: 2.2-fold (0.35 log units) above, and the stated range covers the measured number.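

In this assay the change to 3-hydroxyphenyl from 2-hydroxyphenyl carries over to a second core with an at least 6.1-fold lower number from compound 2 to compound 4 (0.79 log units; beyond the scatter) and points the same way on both cores: the same change on two cores in this assay, an at least 3.5-fold lower number (0.54 log units; beyond the scatter) from compound 1 to compound 3 and an at least 6.1-fold lower number (0.79 log units; beyond the scatter) from compound 2 to compound 4; the limit leaves it open whether they differ
Both sizes stay open-ended, since compound 1 and compound 2 each sit at a limit: the limit of > 50000 nM in this assay, at which 2 of the 4 values shown sit.
4-fluorophenyl in place of 3-fluorophenyl gives a 1.8-fold lower number from compound 3 to compound 4 (0.24 log units; within the scatter) on this core, while the same change on the core of compound 1 cannot be read, so it has no comparison across cores.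

Still open, on these data alone, is whether the 4-hydroxyphenyl group is needed at all. Also open, as far as these compounds go, is how a methoxy group or an amine in place of the hydroxyl on either ring would read in this assay on these cores.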